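This account rests on a few compounds, and the source may have more. Where it says the series, first, only, none or still open, it means among the compounds named here.

Three compounds sharing one core stand in an ADME assay on Vero cells (Chlorocebus sabaeus) for cytotoxicity, read by MTT assay, with a stated time of 72 h; on this read-out higher numbers stand for lower toxicity in this test and lower numbers for higher toxicity in this test: compound 1 `C[C@]1(CN2CCc3nc(C(F)(F)F)ccc3C2)Cn2cc([N+](=O)[O-])nc2O1`, compound 2 `C[C@]1(CN2CCc3nc(-c4ccc(C#N)cc4)ccc3C2)Cn2cc([N+](=O)[O-])nc2O1` and compound 3 `C[C@]1(CN2CCc3nc(-c4cc(F)ccc4Cl)ccc3C2)Cn2cc([N+](=O)[O-])nc2O1`. Compound 1 is recorded as "not determined" (no result reported). Compound 2 is recorded as "not determined" (no result reported). Compound 3 gives > 32 ug/mL, which is a limit of this assay and not a number. Within the data shown here, the whole record therefore comes down to the limit of > 32 ug/mL in this assay, at which 1 of the 3 values shown sits, so compound 3 has no exact position, and no measured step links any of the three.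

Compound 4 `C[C@]1(CN2CCc3nc(-c4ccc(Cl)cc4F)ccc3C2)Cn2cc([N+](=O)[O-])nc2O1` keeps the shared core and has the same atoms as compound 3, joined differently: 4-chloro-2-fluorophenyl in place of 2-chloro-5-fluorophenyl on an aromatic carbon. In words, 4-chloro-2-fluorophenyl stands in place of 2-chloro-5-fluorophenyl on an aromatic carbon, next to the ring nitrogen. Among the measured compounds shown here, the two groups match in everything counted, and no pair of compounds here shows what such a rearrangement does in this assay. No shift beyond the usual scatter is expected, in either direction, and the estimated change is a number no higher from compound 3 to compound 4 (the limit leaves the size open). A report of compound 4 as a limit alone is the likeliest outcome. For compound 4 the expected value is 32 ug/mL, with an estimated range from 16 ug/mL to 64 ug/mL.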

Compound 4, half-maximal cytotoxic concentration: > 32 ug/mL
Compound 4: no number, only a limit; the forecaster's own chance of this, stated with the estimate: 75%; the middle value lies on the limit itself.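

In this assay compound 4 gives > 32 ug/mL as a limit of the assay and not a number. Among these compounds, compound 3 also stands at a limit, so no step between compound 3 and compound 4 can be read: the limit of > 32 ug/mL in this assay, at which 2 of the 4 values shown sit. The compounds shown leave open where compound 3 and compound 4 truly stand, and whether 4-chloro-2-fluorophenyl in place of 2-chloro-5-fluorophenyl changes the read-out at all.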